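Swapping the acyl group on a shared amide core

A few compounds are considered here, and "the series" means these few. Any claim that something is new, unique, unknown or untested is made for them only; others in the source may bear on it.

Measured compounds:
compound 1, `C#CC(=O)N(Cc1ccc(OC)c(O)c1)c1cc(OC)c(OC)c(OC)c1`: 310 nM
compound 2, `COc1ccc(CN(C(C)=O)c2cc(OC)c(OC)c(OC)c2)cc1O`: 270 nM
compound 3, `C=C(C)C(=O)N(Cc1ccc(OC)c(O)c1)c1cc(OC)c(OC)c(OC)c1`: 200 nM

The three compounds share one core and differ only in the group on the carbonyl carbon of the amide. In a functional assay on HCT-116 cells (Homo sapiens) for inhibition, read by MTT assay, with a stated time of 48 h (a lower number here means a stronger inhibitor, a higher number a weaker inhibitor), compound 3 gives the lowest of the three numbers, yet every step among them lies within the scatter: a 1.1-fold lower number from compound 1 to compound 2 (0.06 log units; within the scatter), a 1.6-fold lower number from compound 1 to compound 3 (0.19 log units; within the scatter) and a 1.4-fold lower number from compound 2 to compound 3 (0.13 log units; within the scatter). Three different groups on that carbonyl carbon thus gave no change that can be told apart from repeat noise.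

Compound 4, `COc1ccc(CN(C(=O)CN=[N+]=[N-])c2cc(OC)c(OC)c(OC)c2)cc1O`, continues the same series with another change at the same place: azidomethyl in place of 1-methylethenyl on a carbonyl carbon. All three measured steps bear on this one, since each swapped the group on the carbonyl carbon, and none moved the number beyond the scatter. The expectation is therefore no step beyond the scatter in this assay, so a 1.5-fold higher number from compound 3 to compound 4 (0.18 log units; within the scatter) is expected. Compound 4 is estimated to give 300 nM, with a range from 120 nM to 800 nM.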

Compound 4, half-maximal inhibitory concentration: 410 nM
Compound 4: the middle estimate sits 1.4-fold (0.14 log units) below what was measured; the measured number falls inside the stated range.
By their numbers in this assay, from the lowest: compounds 3, 2, 1 and 4 (each within the scatter of the next, the first and the last beyond it).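

In this assay, this position now shows its first step beyond the scatter, though a modest one (a 2.1-fold higher number from compound 3 to compound 4 (0.31 log units; beyond the scatter)). That step spans only the two ends of the range: azidomethyl stays within the scatter of the other two groups (a 1.5-fold higher number from compound 2 to compound 4 (0.18 log units; within the scatter); a 1.3-fold higher number from compound 1 to compound 4 (0.12 log units; within the scatter)), so the four groups on the carbonyl carbon form a narrow, overlapping band rather than clear ranks. Nothing measured here explains why the swap of 1-methylethenyl for azidomethyl gives this step.

Still open, on these data alone, is whether a different kind of group on the carbonyl carbon, such as an aminomethyl group, a carboxylic acid or a longer carbon chain, would move the number further than this. As far as these compounds go, it is also open whether azidomethyl would give a similar step on a different core.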